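Hydroxyl position on the aryl arms and PC-12 tolerance

The compounds below may be only part of what the source reports. "The series", "measured", "known", "first", "only" and "open" are said of these compounds alone.

Measured in an ADME assay on PC-12 cells (Rattus norvegicus) for cytotoxicity, read by WST assay, with a stated time of 24 h; a lower number here means that less compound is tolerated, a higher number that more compound is tolerated:
- Compound 1 `O=C(/C=C/c1cccc(O)c1)/C=C/c1ccc(O)c(O)c1`: > 100000 nM, a limit of the assay and not a number
- Compound 2 `O=C(/C=C/c1ccccc1O)/C=C/c1cccc(O)c1O`: 54000 nM
- Compound 3 `O=C(/C=C/c1cccc(O)c1)/C=C/c1cccc(O)c1O`: 46000 nM

Among the compounds with values here, only two of the three values are numbers, and they lie within the scatter of each other: a 1.2-fold lower number from compound 2 to compound 3 (0.07 log units; within the scatter). Compound 3 therefore stands level with compound 2, while compound 1 gives only a limit.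

Compound 4 `O=C(/C=C/c1ccc(O)cc1)/C=C/c1cccc(O)c1O` is the next case. Its difference from compound 3 is 4-hydroxyphenyl in place of 3-hydroxyphenyl on a double-bonded chain carbon bound to a double-bonded chain carbon, so 4-hydroxyphenyl replaces 3-hydroxyphenyl on a double-bonded chain carbon bound to a double-bonded chain carbon.

Within the data shown here, one measured step bears on this change, as it swaps hydroxyphenyl groups at the same place: a 1.2-fold lower number from compound 2 to compound 3 (0.07 log units; within the scatter). That step stayed within the scatter, and it is a single example. No step beyond the scatter is therefore expected in this assay, and no direction is favoured. The expected step is a 1.1-fold higher number from compound 3 to compound 4 (0.04 log units; within the scatter). A reading of compound 4 at the limit of > 100000 nM in this assay, at which 1 of the 3 values shown sits, remains possible but is not the expected outcome. For compound 4 the estimated value is 50000 nM, with an expected range from 25000 nM to 100000 nM.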

Compound 4, half-maximal cytotoxic concentration in the PC-12 assay: 12000 nM
Compound 4: the middle estimate sits 4.2-fold (0.62 log units) above what was measured; measured number below the stated range.
By their numbers in the PC-12 assay, from the lowest: compound 4; then compounds 3 and 2 (each within the scatter of the next). At a limit, above all of these: compound 1.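

Notes on the series: in the PC-12 assay compound 4 gives 12000 nM, and the position of the hydroxyl on this arm now separates compounds, as 4-hydroxyphenyl gives a step beyond the scatter both against 3-hydroxyphenyl (a 3.8-fold lower number from compound 3 to compound 4 (0.58 log units; beyond the scatter)) and against 2-hydroxyphenyl (a 4.5-fold lower number from compound 2 to compound 4 (0.65 log units; beyond the scatter)), whereas the only earlier swap at this place stayed within it. Compound 4 thus stands apart from compounds 2 and 3, which remain level with each other, although this rests on one pair of arms and on modest steps. In a physicochemical assay for solubility, using the shake flask method, with a stated time of 12 h (a lower number here means a less soluble compound, a higher number a more soluble compound), compound 3 gives 184000 nM and compound 4 gives 120000 nM, and the same change stays within the scatter (a 1.5-fold lower number from compound 3 to compound 4 (0.19 log units; within the scatter)), so the step in tolerance has no matching step in solubility, and nothing shown accounts for it.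

Open, on these data alone, is whether 4-hydroxyphenyl lowers the number to a similar extent when the other arm of the shared core carries a different hydroxyl pattern. Also open, as far as these compounds go, is what the PC-12 assay would read with a methoxy group or an amine in place of the hydroxyl of 4-hydroxyphenyl, which would test whether the hydroxyl itself is needed for the step.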